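A few compounds are considered here, and "the series" means these few. Any claim that something is new, unique, unknown or untested is made for them only; others in the source may bear on it.

Values so far in a functional assay on HCT-15 cells (Homo sapiens) for inhibition; a higher number here means a weaker inhibitor of growth, a lower number a stronger inhibitor of growth

compound 1 `COc1cc(/C=C/C(=O)c2cccc(-n3cc(-c4ccc(Cl)cc4)[nH]c3=O)c2)cc(OC)c1OC` gives 3850 nM
compound 2 `COc1cc(/C=C/C(=O)c2cccc(-n3cc(-c4ccccc4)[nH]c3=O)c2)ccc1O` gives 2730 nM

Compound 1 has the higher of the two numbers, but the gap to compound 2 lies within the scatter, so the two cannot be told apart in this assay and neither ranks above the other.

Among the compounds with values here, compound 3 `COc1ccc(-c2cn(-c3cccc(C(=O)/C=C/c4cc(OC)c(OC)c(OC)c4)c3)c(=O)[nH]2)cc1` has no measurement yet. It departs from compound 1 by a single change methoxy in place of chloro on an aromatic carbon as methoxy in place of chloro on an aromatic carbon, para to a large group, which reads 4-chlorophenyl to 4-methoxyphenyl.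

Within the data shown here, the series offers no step between measured compounds that differ in one place, so the data give no direct size for this change. Among the measured compounds shown here, the only anchors are compound 1 (3850 nM) and compound 2 (2730 nM), whose values fall within the scatter of each other. No shift beyond the scatter is expected in this assay, and no direction can be held with confidence. The estimate amounts to a 1.3-fold lower number from compound 1 to compound 3 (0.11 log units; within the scatter) and is expected to stay within the scatter. For compound 3 the estimated value is 3000 nM, with an expected range from 1100 nM to 8000 nM around that estimate.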

Compound 3, concentration for 50% growth inhibition: 1380 nM
Estimate against measurement, compound 3: 2.2-fold (0.34 log units) above, within the range that was stated.
By their numbers in this assay, from the lowest: compounds 3, 2 and 1 (each within the scatter of the next, the first and the last beyond it).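

In this assay the series now has its first step between measured compounds that differ in one place, 4-chlorophenyl to 4-methoxyphenyl (a 2.8-fold lower number from compound 1 to compound 3 (0.45 log units; beyond the scatter)), a modest step beyond the scatter. It shows that the group on this aromatic carbon, para to a large group, can move the growth-inhibition read-out, with methoxy in place of chloro giving the lower number; the earlier pair could not show this, as compound 1 and compound 2 differ in more than one place and lie within the scatter of each other. Nothing at hand bears on the reason for this step.

As far as these compounds go, this step rests on a single pair, so it remains open whether the same change would give a step of similar size on the core of compound 2, where the other aromatic ring is substituted differently. From the compounds shown here alone, it also remains open how an amine, a carboxylic acid or a longer ether such as ethoxy would read at this position, and so whether the lower number is particular to methoxy or is shared by other replacements for chloro.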